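The source may report more compounds than this note shows. Statements on the series, on what has been measured and on what is new or still open speak of the compounds shown alone.

In a physicochemical assay for lipophilicity, measured as octanol-water partition (a higher number here means a more lipophilic compound, a lower number a more polar compound), compound 2 (`C=C(C)c1ccccc1NC(=S)c1ccc(O)cc1O`) stands highest of the three measured compounds, at 4.27 on this scale. Compound 3 (`O=[N+]([O-])c1cc(NC(=S)c2ccc(O)cc2O)ccc1F`) reads 3.43 and compound 1 (`COc1ccc(NC(=S)c2ccc(O)cc2O)cc1O`) reads 2.39 here, both beyond the scatter from compound 2. Compound 4 (`Oc1ccc(C(=S)Nc2ccccc2-n2cccc2)c(O)c1`) differs from compound 2 in one place, with 1H-pyrrol-1-yl in place of 1-methylethenyl on an aromatic carbon. Within the data shown here, the series holds no step between measured compounds, so the expectation rests on the structural change alone. In this assay a small fall is expected, not clearly beyond the scatter, with a number 0.27 log units lower from compound 2 to compound 4 (within the scatter) as the estimated step. For compound 4 the estimated value is 4 with an expected range from 3.5 to 4.5 for now.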

Compound 4, partition coefficient: 3.29
For compound 4 the middle estimate is 0.71 log units above the measured one, outside the stated range (below it).
By their numbers in this assay, from the lowest: compound 1; then compounds 4 and 3 (each within the scatter of the next); then compound 2.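

In this assay, 1H-pyrrol-1-yl in place of 1-methylethenyl on an aromatic carbon, ortho to a large group, gives a number 0.98 log units lower from compound 2 to compound 4 (beyond the scatter) and is the only one-place step shown in the series. The number at this position therefore responds to the exchange, and it falls although the entering group holds more heavy atoms and adds a five-membered aromatic ring. Nothing measured here bears on what lies behind this step. Open, going by these compounds, is how an amine or a carboxylic acid at this position would read, and whether the same exchange gives a similar step on another core.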